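Phenyl to Methyl on the Chain: Expected Solubility

A few compounds are considered here, and "the series" means these few. Any claim that something is new, unique, unknown or untested is made for them only; others in the source may bear on it.

Measured so far:
Compound 1, `O=C(NCCCCc1ccccc1)n1cc(-c2ccccc2)oc1=O`: in a physicochemical assay for solubility, read by HPLC, in phosphate buffer, measured as kinetic solubility, with a stated time of 1 h, at pH 7.4, tested at 250 uM (on this read-out higher numbers stand for higher solubility and lower numbers for lower solubility), compound 1 gives < 1000 nM, which is a limit of the assay and not a number.
Compound 2, `CCCCCNC(=O)n1cc(-c2ccccc2)oc1=O`: in this assay compound 2 gives < 1000 nM, again a limit of the assay.
Compound 3, `CN1CCC(c2cc(F)ccc2-c2cn(C(=O)NCCCCc3ccccc3)c(=O)o2)CC1`: in this assay compound 3 gives 60000 nM.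

Compound 2 differs from compound 1 by methyl in place of phenyl on a saturated chain carbon, four bonds along the chain from an amide-type nitrogen. The step that the two limits leave unreadable from compound 1 to compound 2 stays unreadable because the limit of < 1000 nM in this assay, at which 2 of the 3 values shown sit, hides both ends of it.

Compound 4, `CCCCCNC(=O)n1cc(-c2ccc(F)cc2C2CCN(C)CC2)oc1=O`, has not yet been measured in this assay. It differs from compound 3 by methyl in place of phenyl on a saturated chain carbon, four bonds along the chain from an amide-type nitrogen, the same change as that from compound 1 to compound 2. How the core of compound 3 differs from the core of compound 1 is not broken down here.

With the measured step unreadable, the expectation rests on compound 3 alone and its value 60000 nM in this assay. The step of a 2.0-fold higher number from compound 3 to compound 4 (0.30 log units; within the scatter) is expected to be modest, leaning upward. Compound 4 is therefore estimated to give 120000 nM in this assay, most likely between 40000 nM and 250000 nM.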

Compound 4, solubility: > 250000 nM
Compound 4: only a limit was reported (the forecaster's own chance of this, stated with the estimate: 15%); middle value at least 2.0-fold (0.31 log units) from the limit.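

On the core of compound 3, methyl in place of phenyl on the saturated chain gives an at least 4.1-fold higher number from compound 3 to compound 4 (0.61 log units; beyond the scatter) in this assay, so on this core the change reads clearly beyond the usual scatter of the measurement. Compound 4 gives > 250000 nM, which is a limit of the assay and not a number. The change is therefore seen on one core only and cannot be said to carry over, because the step from compound 1 to compound 2 cannot be read: the limit of < 1000 nM in this assay, at which 2 of the 4 values shown sit.

The compounds shown leave open whether the step follows from losing the phenyl ring or from the shorter chain, as the two go together in this change. Also open, as far as these compounds go, is how a longer chain ending in methyl, or a chain ending in an amine or a carboxylic acid, would read in this assay on the core of compound 3.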